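This account rests on a few compounds, and the source may have more. Where it says the series, first, only, none or still open, it means among the compounds named here.

Measured in a functional assay on HepG2 cells (Homo sapiens) for antiproliferative activity, read by MTT assay, with a stated time of 72 h; on this read-out lower numbers stand for stronger inhibition and higher numbers for weaker inhibition:
compound 1 `COc1ccc(N2C(=O)COc3ccc(-c4cnc(OC)c(NS(=O)(=O)c5ccc(F)cc5)c4)cc32)cc1`: 13100 nM
compound 2 `COc1ncc(-c2ccc3c(c2)N(C2CCCCC2)C(=O)CO3)cc1NS(=O)(=O)c1ccc(F)cc1`: reported only as a limit of the assay, > 40000 nM
compound 3 `COc1ncc(-c2ccc3c(c2)N(C(C)C)C(=O)CO3)cc1NS(=O)(=O)c1ccc(F)cc1`: 37200 nM

Compound 3 holds the highest of the two numbers; the nearest is compound 1, with a 2.8-fold higher number from compound 1 to compound 3 (0.45 log units; beyond the scatter). Compound 2 sits at the limit (the limit of > 40000 nM in this assay, at which 1 of the 3 values shown sits), and an at least 1.0-fold lower number from compound 2 to compound 3 (0.03 log units; that floor lies within the scatter).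

Compound 4 `COc1cccc(N2C(=O)COc3ccc(-c4cnc(OC)c(NS(=O)(=O)c5ccc(F)cc5)c4)cc32)c1` carries 3-methoxyphenyl in place of isopropyl on an amide-type nitrogen in a ring. Within the data shown here, the steps that bear on it are a 2.8-fold higher number from compound 1 to compound 3 (0.45 log units; beyond the scatter) and an at least 3.0-fold higher number from compound 1 to compound 2 (0.48 log units; beyond the scatter), both showing a lower number for the methoxyphenyl on that nitrogen than for the alkyl groups. Compound 4 is therefore expected to move back toward compound 1, with a 2.7-fold lower number from compound 3 to compound 4 (0.42 log units; beyond the scatter). The estimate for compound 4 is 14000 nM, in the range 6000 nM to 35000 nM.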

Compound 4, half-maximal inhibitory concentration: > 40000 nM
Compound 4 was reported as a limit; the forecaster's own chance of this, stated with the estimate: 10%; at least 2.8-fold (0.45 log units) between middle value and limit.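

With 3-methoxyphenyl in place of 4-methoxyphenyl on the amide-type nitrogen, the series shows an at least 3.0-fold higher number from compound 1 to compound 4 (0.48 log units; beyond the scatter), so a methoxyphenyl group there does not by itself keep the number of compound 1. Against isopropyl, the change gives an at least 1.0-fold higher number from compound 3 to compound 4 (0.03 log units; that floor lies within the scatter), so 3-methoxyphenyl cannot be ordered relative to isopropyl. The step from compound 2 to compound 4 cannot be read, since both values are limits: the limit of > 40000 nM in this assay, at which 2 of the 4 values shown sit.

Still open, from the compounds shown here alone, is whether 4-hydroxyphenyl, 4-fluorophenyl or benzyl on this nitrogen would give a number near that of compound 1.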